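Replacing an anilide by a benzyl amide on the dihydrofuran core

A few compounds are considered here, and "the series" means these few. Any claim that something is new, unique, unknown or untested is made for them only; others in the source may bear on it.

Compound 1 `C=CC1=C(C(=O)Nc2ccc(C)cc2)C(c2ccc(F)cc2)OC1`: > 100000 nM
Compound 2 `C=CC1=C(C(=O)NCc2ccc(C)cc2)C(c2ccc(OC)cc2)OC1`: 15900 nM
Compound 3 `C=CC1=C(C(=O)Nc2cccc(C)c2)C(c2ccc(F)cc2)OC1`: "not active" (no number reported)

In a functional assay on HeLa cells (Homo sapiens) for cytotoxicity, read by MTT assay, with a stated time of 24 h (a lower number here means a stronger inhibitor, a higher number a weaker inhibitor), compound 3 is reported only as "not active" (no number reported), with no number given. Compound 1 sits at the limit of > 100000 nM in this assay, at which 1 of the 3 values shown sits, which is a limit of this assay and not a number. Compound 2 gives 15900 nM in this assay. The step to compound 4 `C=CC1=C(C(=O)NCc2ccc(C)cc2)C(c2ccc(F)cc2)OC1` brings (4-methylbenzyl in place of 3-methylphenyl on an amide-type nitrogen). Going by the values given here, no measured step of this kind is available, so its size is unknown; a change toward a measurable value, beyond the scatter, is expected, because compound 2, which also carries the 4-methylbenzyl, gives 15900 nM. Compound 4 is therefore estimated at 30000 nM in this assay, with a range from 8000 nM to 100000 nM.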

Compound 4, half-maximal inhibitory concentration: > 100000 nM
Compound 4: only a limit was reported (the forecaster's own chance of this, stated with the estimate: 45%); at least 3.3-fold (0.52 log units) between middle value and limit.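

In this assay compound 4 gives > 100000 nM as a limit of the assay and not a number. Fluoro in place of methoxy on an aromatic carbon brings an at least 6.2-fold higher number from compound 2 to compound 4 (0.79 log units; beyond the scatter) and is beyond the scatter, so in this pair the 4-methylbenzyl on the amide-type nitrogen gives a measurable value only alongside the methoxy. The step from the 4-methylphenyl amide cannot be read, since both ends are limits. Still open, on these data alone, is whether a hydroxyl or a dimethylamino group in place of the fluoro would give a measurable value, and whether methoxy does so with a 4-methylphenyl on that nitrogen.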